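Losing the (methylsulfanyl)methyl group from compound 1

A few compounds are considered here, and "the series" means these few. Any claim that something is new, unique, unknown or untested is made for them only; others in the source may bear on it.

In an ADME assay on microsomes from liver (Homo sapiens) for metabolic stability (a higher number here means that the compound lasts longer, a lower number that the compound disappears faster), compound 1 (`COC[C@H](NC(=O)c1cc(C)on1)C(=O)N[C@@H](CSC)C(=O)N[C@@H](CC(C)C)C(=O)[C@@]1(C)CO1`) gives 0.283 h, the higher of the two numbers measured, while compound 2 (`CSC[C@H](NC(=O)c1cc(C)on1)C(=O)N[C@@H](CSC)C(=O)N[C@@H](CC(C)C)C(=O)[C@@]1(C)CO1`) gives 0.108 h. Compound 3 (`COC[C@H](NC(=O)c1cc(C)on1)C(=O)NCC(=O)N[C@@H](CC(C)C)C(=O)[C@@]1(C)CO1`) has hydrogen in place of (methylsulfanyl)methyl on a saturated chain carbon bound to an amide-type nitrogen and a carbonyl carbon. For the measured compounds named here, the only measured step is a 2.6-fold lower number from compound 1 to compound 2 (0.42 log units; beyond the scatter), with methylsulfanyl in place of methoxy. That is a different change, so it bears only indirectly, yet it suggests that losing a methylsulfanyl group may not lower this assay. A small upward move is expected, a 1.4-fold higher number from compound 1 to compound 3 (0.15 log units; within the scatter). For compound 3 the estimated value is 0.4 h, within an expected range of 0.15 h to 1 h.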

Compound 3, half-life: 1.86 h
For compound 3 the middle estimate is 4.7-fold (0.67 log units) below the measured one, outside the stated range (above it).
By their numbers in this assay, from the lowest: compound 2; then compound 1; then compound 3.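

Hydrogen in place of (methylsulfanyl)methyl on a saturated chain carbon bound to an amide-type nitrogen and a carbonyl carbon gives a 6.6-fold higher number from compound 1 to compound 3 (0.82 log units; beyond the scatter) in this assay. For the compounds shown here, the earlier step, methylsulfanyl in place of methoxy, concerned a different place, so this is the first sign that the number also responds to the group at this position, and it rises when that group is removed. Still open, as far as these compounds go, is whether a methyl group, a longer chain or an amine at this carbon would keep that gain, and whether the same change would act alike on compound 2. No measurement at hand accounts for the rise.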